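Rat prostate 5-alpha-reductase series: N-substituent chain extension

The source may report more compounds than this note shows. Statements on the series, on what has been measured and on what is new or still open speak of the compounds shown alone.

Measured so far:
Compound 1, `CCCCn1ccc2cc(/C(C)=C/C(=O)Nc3ccccc3OCCCC(=O)O)ccc21`, in an assay on Prostate gland for inhibition of steroid 5-alpha-reductase (Rattus norvegicus) (on this read-out lower numbers stand for stronger inhibition and higher numbers for weaker inhibition), gives 43 nM.
Compound 2, `CCCCCn1ccc2cc(/C(C)=C/C(=O)Nc3ccccc3OCCCC(=O)O)ccc21`, gives 23 nM.
Compound 3, `CCCC(c1ccccc1)n1ccc2cc(/C(C)=C/C(=O)Nc3ccccc3OCCCC(=O)O)ccc21`, gives 9.1 nM.

Compound 3 gives the lowest of the three numbers. Its core differs from that of compound 1 by phenyl in place of hydrogen on a saturated chain carbon bound to an aromatic nitrogen and a saturated chain carbon, a change that brings a 4.7-fold lower number from compound 1 to compound 3 (0.67 log units; beyond the scatter). From compound 2 to compound 3 the step is a 2.5-fold lower number from compound 2 to compound 3 (0.40 log units; beyond the scatter).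

Compound 4, `CCCCC(c1ccccc1)n1ccc2cc(/C(C)=C/C(=O)Nc3ccccc3OCCCC(=O)O)ccc21`, has not yet been measured. It differs from compound 3 by methyl in place of hydrogen on a saturated chain carbon, four bonds along the chain from an aromatic carbon and an aromatic nitrogen. The same kind of change is already on record once, from compound 1 to compound 2: there it was methyl in place of hydrogen on a saturated chain carbon, four bonds along the chain from an aromatic nitrogen and it brought a 1.9-fold lower number from compound 1 to compound 2 (0.27 log units; within the scatter). The two places are not the same word for word: in compound 1 the chain carbon sits four bonds along the chain from an aromatic nitrogen, whereas in compound 3 it sits four bonds along the chain from an aromatic carbon and an aromatic nitrogen, the aromatic carbon being part of the phenyl that compound 3 carries. The change is therefore of the same kind, not the same.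

For compound 4 in this assay a step of about a 1.5-fold lower number from compound 3 to compound 4 (0.18 log units; within the scatter) is expected, resting on the earlier step of a 1.9-fold lower number from compound 1 to compound 2 (0.27 log units; within the scatter). Compound 3 gives 9.1 nM. Resting on that number, the expected number for compound 4 is 6 nM, with a range of 2.5 nM to 15 nM.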

Compound 4, half-maximal inhibitory concentration: 9.8 nM
Estimate against measurement, compound 4: 1.6-fold (0.21 log units) below; the measured number falls inside the stated range.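

Within this assay, methyl in place of hydrogen on the chain of the phenyl-bearing core gives a 1.1-fold higher number from compound 3 to compound 4 (0.03 log units; within the scatter), and this step does not differ beyond the scatter from the one on the core without phenyl: the same change on two cores in this assay, a 1.9-fold lower number (0.27 log units; within the scatter) from compound 1 to compound 2 and a 1.1-fold higher number (0.03 log units; within the scatter) from compound 3 to compound 4, 2.0-fold (0.30 log units) apart, within the scatter of two such steps. The phenyl change also carries over to the longer chain, where it gives a 2.3-fold lower number from compound 2 to compound 4 (0.37 log units; beyond the scatter), and its size on the two cores agrees within the scatter, while the combined change of 1-phenylpentyl in place of butyl gives a 4.4-fold lower number from compound 1 to compound 4 (0.64 log units; beyond the scatter): the same change on two cores in this assay, a 4.7-fold lower number (0.67 log units; beyond the scatter) from compound 1 to compound 3 and a 2.3-fold lower number (0.37 log units; beyond the scatter) from compound 2 to compound 4, 2.0-fold (0.30 log units) apart, within the scatter of two such steps. Going by these compounds alone, these results show that, for these four compounds, each change reads about the same on both cores, but each rests on only one pair of steps, so a small real difference between cores cannot be excluded and no rule for other cores follows.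

As far as these compounds go, it remains open whether the pattern holds for a longer chain, such as 1-phenylhexyl, on the aromatic nitrogen. Also open, from the compounds shown here alone, is whether a cyclohexyl group in place of phenyl, or a fluorine or methoxy group on that phenyl, would behave in the same way on these cores.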